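A few compounds are considered here, and "the series" means these few. Any claim that something is new, unique, unknown or untested is made for them only; others in the source may bear on it.

Three compounds in the series have been run in a functional assay on HepG2 cells (Homo sapiens) for antiproliferative activity, read by MTT assay, with a stated time of 48 h; a higher number here means a weaker inhibitor, a lower number a stronger inhibitor. Compound 1 `N#CC1=C(N)Oc2c(c3nc4ccccc4nc3c3ccccc23)C12C(=O)N(Cc1cnnn1-c1ccc(F)c(Cl)c1)c1ccccc12` and compound 2 `N#CC1=C(N)Oc2c(c3nc4ccccc4nc3c3ccccc23)C12C(=O)N(Cc1cnnn1-c1ccc(Cl)c(Cl)c1)c1ccccc12` share one core; compound 3 `N#CC1=C(N)Oc2c(N)cc3nc4ccccc4nc3c2C12C(=O)N(Cc1cnnn1-c1ccc(F)cc1)c1ccccc12` is built on a different core, and the difference between the two cores is not broken down here. In this assay compound 1 gives > 50000 nM, which is a limit of the assay and not a number. Compound 2 likewise returns only a limit, > 50000 nM. Compound 3 too reaches only a limit, > 50000 nM. The change from compound 1 to compound 2 is chloro in place of fluoro on an aromatic carbon, and the step it made, a step that the two limits leave unreadable from compound 1 to compound 2, cannot be read because of the limit of > 50000 nM in this assay, at which 3 of the 3 values shown sit.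

Compound 4 `N#CC1=C(N)Oc2c(N)cc3nc4ccccc4nc3c2C12C(=O)N(Cc1cnnn1-c1ccc(Cl)cc1)c1ccccc12` has not yet been measured. It differs from compound 3 by chloro in place of fluoro on an aromatic carbon. This is the same kind of change as that between compound 1 and compound 2, though not the same change: in compound 1 the aromatic carbon is also ortho to a chloro group, whereas in compound 3 it is para to a large group only. For the measured compounds named here, with every measured value of the series sitting at the limit, and the one measured instance of this kind of change leaving no readable step, the expected step here is a step that the limit leaves unreadable from compound 3 to compound 4, resting on compound 3 having given > 50000 nM in this assay. Compound 4 is therefore estimated at 60000 nM in this assay, most likely reported as a limit again, with a plausible range from 30000 nM to 150000 nM.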

Compound 4, half-maximal inhibitory concentration: > 50000 nM
Compound 4 gave a limit, no number; the forecaster's own chance of this, stated with the estimate: 85%; the middle value is on the limit's open side.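

No step can be read between compound 3 and compound 4, because each gives a limit of the assay and not a number: the limit of > 50000 nM in this assay, at which 4 of the 4 values shown sit.

The compounds shown leave open whether chloro in place of fluoro on an aromatic carbon, or the difference between the two cores, changes the result in this assay at all, and what structure in this series would give a readable value.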